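Chloro in Place of Methyl: Expectation for Compound 4

The source may report more compounds than this note shows. Statements on the series, on what has been measured and on what is new or still open speak of the compounds shown alone.

Measured compounds:
Compound 1 `CC1=CC[C@@H]([C@@](C)(O)CCCC(C)(C)NC(=S)N/N=C\c2ccc(C)cc2)CC1` gives 6020 nM in a functional assay on OVCAR-3 cells (Homo sapiens) for cytotoxicity, read by sulforhodamine B assay; a higher number here means a weaker inhibitor of growth, a lower number a stronger inhibitor of growth.
Compound 2 `CC1=CC[C@@H]([C@@](C)(O)CCCC(C)(C)NC(=S)N/N=C\c2ccc(O)cc2)CC1` gives 6230 nM in this assay.
Compound 3 `CC1=CC[C@@H]([C@@](C)(O)CCCC(C)(C)NC(=S)N/N=C\c2ccccc2[N+](=O)[O-])CC1` gives 7390 nM in this assay.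

Compound 1 has the lowest number of the three, but its neighbours sit close: a 1.0-fold higher number from compound 1 to compound 2 (0.01 log units; within the scatter) and a 1.2-fold higher number from compound 1 to compound 3 (0.09 log units; within the scatter) are both within the scatter, so the three compounds cannot be told apart on these numbers. Compound 4 `CC1=CC[C@@H]([C@@](C)(O)CCCC(C)(C)NC(=S)N/N=C\c2ccc(Cl)cc2)CC1` differs from compound 1 by chloro in place of methyl on an aromatic carbon.

For the measured compounds named here, no measured step exchanges methyl for chloro at that place. The nearest comparisons are other changes on the same aromatic ring: a 1.0-fold higher number from compound 1 to compound 2 (0.01 log units; within the scatter) and a 1.2-fold higher number from compound 2 to compound 3 (0.07 log units; within the scatter), each within the scatter. These suggest that the aromatic ring tolerates such exchanges without a clear shift in this assay.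

The step of a 1.0-fold lower number from compound 1 to compound 4 (0.00 log units; within the scatter) is therefore expected to lie within the scatter. Compound 4 is estimated at 6000 nM, with a range from 3000 nM to 12000 nM.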

Compound 4, concentration for 50% growth inhibition: 6660 nM
Compound 4: middle estimate off by 1.1-fold (0.05 log units), on the low side; low and high end bracket the measured number.
By their numbers in this assay, from the lowest: compounds 1, 2, 4 and 3 (each within the scatter of the next).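

In this assay, the direct exchange of methyl for chloro on this aromatic carbon gives a 1.1-fold higher number from compound 1 to compound 4 (0.04 log units; within the scatter) and so adds a measured step where the opening had only nearby changes. Chloro in place of hydroxy at the same place gives a 1.1-fold higher number from compound 2 to compound 4 (0.03 log units; within the scatter) as well, while 4-chlorophenyl in place of 2-nitrophenyl, which also moves the ring substituent, gives a 1.1-fold lower number from compound 3 to compound 4 (0.05 log units; within the scatter) and likewise separates nothing, so methyl, hydroxy and chloro at this place cannot be told apart on these numbers. No measurement at hand explains this tolerance.

On these data alone, whether an amine, a carboxylic acid or a longer chain on this aromatic carbon would shift the number beyond the scatter stays open. Also open, as far as these compounds go, is whether changes elsewhere on the shared core matter more than changes on this ring.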